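One Further Stereocentre Inverted

The source may report more compounds than this note shows. Statements on the series, on what has been measured and on what is new or still open speak of the compounds shown alone.

In a functional assay on KB cells (Homo sapiens) for cytotoxicity (on this read-out higher numbers stand for weaker inhibition and lower numbers for stronger inhibition), compound 2 (`CCCCCCCCCCCCCC[C@H]1N[C@@H](CO)[C@@H]1O`) gives 3.2 ug/mL and stands level, within the scatter, with compound 1 (`CCCCCCCCCCCCCC[C@@H]1N[C@@H](CO)[C@@H]1O`) at 3.4 ug/mL on the same read-out. Compound 3 (`CCCCCCCCCCCCCC[C@H]1N[C@@H](CO)[C@H]1O`) differs from compound 2 (the two compounds have the same atoms and bonds and differ only in configuration as drawn: 1 of 3 stereo elements differ; a stereocentre at a saturated ring carbon is drawn R in compound 2 and S in compound 3) at a stereocentre at a saturated ring carbon, drawn R in compound 2 and S in compound 3. Among the measured compounds shown here, the one measured change of configuration is a 1.1-fold lower number from compound 1 to compound 2 (0.03 log units; within the scatter) and it is the sole guide, so in this assay no step beyond the scatter is expected in either direction. Compound 3 is therefore estimated at 3.3 ug/mL (expected range 1.7 ug/mL to 6.5 ug/mL).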

Compound 3, half-maximal inhibitory concentration: > 10 ug/mL
Compound 3: only a limit was reported; the forecaster's own chance of this, stated with the estimate: 5%; middle value at least 3.0-fold (0.48 log units) away from the limit.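

In this assay, the stereocentre inverted here matters where the earlier inversion did not: that one gave a 1.1-fold lower number from compound 1 to compound 2 (0.03 log units; within the scatter), whereas this one gives an at least 3.1-fold higher number from compound 2 to compound 3 (0.49 log units; beyond the scatter). The value of compound 3, > 10 ug/mL, is a limit of the assay and not a number. With both stereocentres inverted, the result is an at least 2.9-fold higher number from compound 1 to compound 3 (0.46 log units; beyond the scatter).

On these data alone, how far compound 3 lies past its limit remains open. So does whether this stereocentre would count as much in a compound carrying a carboxylic acid on the shared core or a longer chain.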